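A few compounds are considered here, and "the series" means these few. Any claim that something is new, unique, unknown or untested is made for them only; others in the source may bear on it.

In an in vitro functional assay on HEK293 cells for antagonist activity at melanin-concentrating hormone receptor 1 (Homo sapiens), read by GTPgammaS binding, with a stated time of 45 min (on this read-out higher numbers stand for higher potency (the scale is a negative logarithm) and lower numbers for lower potency), the two measured compounds stand as follows:
compound 1 `Cc1ccc(CN2CCC(NC(=O)N(CC(=O)C(C)(C)O)Cc3ccc(-c4ccc(F)cc4)cc3)CC2)cc1` gives 5.34;
compound 2 `Cc1ccc(CN2CCC(CCN(Cc3ccc(-c4ccc(F)cc4)cc3)C(=O)NC(C)C)CC2)cc1` gives 6.42.

Compound 2 holds the higher of these two numbers, and compound 1 lies lower by a margin beyond the usual scatter. Compound 3 `Cc1ccc(CN2CCC(CCN(Cc3ccc(-c4cccc(C#N)c4)cc3)C(=O)NC(C)C)CC2)cc1` differs from compound 2 in one place: 3-cyanophenyl in place of 4-fluorophenyl on an aromatic carbon. No measured pair among these compounds shows a change of this kind, so the direction is open; the step is expected to be small, a number 0.02 log units lower from compound 2 to compound 3 (within the scatter), and not beyond the scatter in either direction. Compound 3 is therefore estimated at 6.4, with a range from 5.7 to 7.1.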

Compound 3, negative logarithm of the antagonist equilibrium constant: 6
Estimate against measurement, compound 3: 0.40 log units above; the measured number falls inside the stated range.
By their numbers in this assay, from the lowest: compound 1; then compound 3; then compound 2.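

In this assay, placing 3-cyanophenyl instead of 4-fluorophenyl on this aromatic carbon, para to a large group, gives a number 0.42 log units lower from compound 2 to compound 3 (beyond the scatter), a modest loss of potency. This is the first one-place comparison among the compounds shown, and it shows that potency responds to the group held at this position. No supporting measurement is available to explain the step.

Still open, going by these compounds, is whether the outcome follows the nitrile itself or where it sits. A 4-cyanophenyl or 3-fluorophenyl group would separate these two readings, and an unsubstituted phenyl would provide a reference for both.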